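Moving the Chlorine Round the Benzylsulfanyl Ring

The source may hold more compounds than are shown below. What is called first, only, known or untested is meant among the compounds shown, and "the series" means these compounds.

Of the compounds shown here, three sharing one core have been measured in a functional assay on MCF7 cells (Homo sapiens) for cytotoxicity, read by MTT assay, with a stated time of 72 h; a higher number here means a weaker inhibitor, a lower number a stronger inhibitor. Compound 1 `Cc1cc(S(=O)(=O)/N=C(\N)n2nccc2-c2ccccc2)c(SCc2ccc(Cl)cc2)cc1Cl` gives 75000 nM, compound 2 `Cc1cc(S(=O)(=O)/N=C(\N)n2nccc2-c2ccccc2)c(SCc2ccccc2Cl)cc1Cl` gives 24000 nM, and compound 3 `Cc1cc(S(=O)(=O)/N=C(\N)n2nccc2-c2ccccc2)c(SCc2ccc(C(F)(F)F)cc2)cc1Cl` gives 25000 nM. Compound 3 therefore holds the second highest of the three numbers; its nearest neighbour is compound 2, with a 1.0-fold higher number from compound 2 to compound 3 (0.02 log units; within the scatter), and its furthest is compound 1, with a 3.0-fold lower number from compound 1 to compound 3 (0.48 log units; beyond the scatter).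

Compound 4 `Cc1cc(S(=O)(=O)/N=C(\N)n2nccc2-c2ccccc2)c(SCc2cccc(Cl)c2)cc1Cl` differs from compound 3 in one place: 3-chlorophenyl in place of 4-(trifluoromethyl)phenyl on a saturated chain carbon bound to a sulfur. Among the measured compounds shown here, no measured step carries exactly this change. For the measured compounds named here, two steps bear on it: the exchange of chloro for trifluoromethyl on an aromatic carbon gave a 3.0-fold lower number from compound 1 to compound 3 (0.48 log units; beyond the scatter), and shifting the chlorine from 4-chlorophenyl to 2-chlorophenyl gave a 3.1-fold lower number from compound 1 to compound 2 (0.49 log units; beyond the scatter). A 3-chlorophenyl group is thus flanked by one chlorophenyl isomer near the top of the range and another near the bottom, so a modest rise in number is expected for compound 4, roughly a 1.6-fold higher number from compound 3 to compound 4 (0.20 log units; within the scatter). Compound 4 is estimated at 40000 nM, within a range of 15000 nM to 100000 nM.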

Compound 4, half-maximal inhibitory concentration: 88000 nM
For compound 4 the middle estimate is 2.2-fold (0.34 log units) below the measured one; measured number inside the range.
By their numbers in this assay, from the lowest: compounds 2 and 3 (each within the scatter of the next); then compounds 1 and 4 (each within the scatter of the next).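

On the saturated chain carbon bound to a sulfur, the position of the chlorine now reads as a split and not a gradient: in this assay, 3-chlorophenyl in place of 2-chlorophenyl gave a 3.7-fold higher number from compound 2 to compound 4 (0.56 log units; beyond the scatter), while 3-chlorophenyl in place of 4-chlorophenyl gave a 1.2-fold higher number from compound 1 to compound 4 (0.07 log units; within the scatter), so only the 2-chlorophenyl isomer stands apart. The 3-chlorophenyl group also falls short of 4-(trifluoromethyl)phenyl, with a 3.5-fold higher number from compound 3 to compound 4 (0.55 log units; beyond the scatter), which shows that a group at the 4-position can match the 2-chlorophenyl result when that group is trifluoromethyl but not when it is chloro. No evidence is available that explains this split.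

As far as these compounds go, whether trifluoromethyl would show the same dependence on ring position as chlorine remains open. So does the outcome with a bromine, a methoxy group or a carboxylic acid on this ring.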